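The compounds below may be only part of what the source reports. "The series", "measured", "known", "first", "only" and "open" are said of these compounds alone.

Measured compounds:
compound 1, `COc1cc2c(Oc3ccc(NC(=O)c4nnn(-c5ccc(C)cc5)c4C(F)(F)F)cc3F)ccnc2cc1OCCCN1CCCC1`, 210 nM
compound 2, `COc1cc2c(Oc3ccc(NC(=O)c4nnn(-c5ccc(F)cc5)c4C(F)(F)F)cc3F)ccnc2cc1OCCCN1CCCCC1`, 40 nM
compound 3, `COc1cc2c(Oc3ccc(NC(=O)c4nnn(-c5ccc(F)cc5)c4C(F)(F)F)cc3F)ccnc2cc1OCCCN1CCC(C)CC1`, 70 nM

In a functional assay on MKN-45 cells (Homo sapiens) for cytotoxicity, read by MTT assay, with a stated time of 72 h (on this read-out higher numbers stand for weaker inhibition and lower numbers for stronger inhibition), compound 3 stands second highest of the three numbers; compound 2 lies nearest, and compound 1 lies furthest. Within the data shown here, the single step measured at one place, a 1.8-fold higher number from compound 2 to compound 3 (0.24 log units; within the scatter), concerns the saturated ring, not the aromatic one. Compound 4, `COc1cc2c(Oc3ccc(NC(=O)c4nnn(-c5ccc(C)cc5)c4C(F)(F)F)cc3F)ccnc2cc1OCCCN1CCC(C)CC1`, differs from compound 3 by methyl in place of fluoro on an aromatic carbon. Among the measured compounds shown here, no measured step isolates this change: compound 1 and compound 2 differ both here and at the saturated ring, so their values show only a combined effect, in which compound 1 gives 210 nM and compound 2 gives 40 nM. On that thin basis compound 4 is expected to give a moderately higher number, a 1.9-fold higher number from compound 3 to compound 4 (0.27 log units; within the scatter), with wide uncertainty. The estimate for compound 4 is 130 nM, in the range 45 nM to 380 nM.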

Compound 4, half-maximal inhibitory concentration: 140 nM
Compound 4: middle estimate off by 1.1-fold (0.03 log units), on the low side; the range from low to high includes it.
By their numbers in this assay, from the lowest: compounds 2, 3, 4 and 1 (each within the scatter of the next, the first and the last beyond it).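

In this assay, the change from 4-fluorophenyl to 4-methylphenyl can now be read on its own (a 2.0-fold higher number from compound 3 to compound 4 (0.30 log units; within the scatter)), so at this aromatic carbon, para to a large group, the two groups cannot be told apart. With the 4-methylphenyl group held in place, the 4-methylpiperidin-1-yl and pyrrolidin-1-yl groups cannot be told apart either (a 1.5-fold lower number from compound 1 to compound 4 (0.18 log units; within the scatter)). Nothing available explains either step. Other groups at this aromatic carbon, such as chloro, methoxy or nitrile, remain open, as does whether this change reads the same with other saturated rings on the chain.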